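Shortening the alkoxy chain on a chloroquinoline-type core

A few compounds are considered here, and "the series" means these few. Any claim that something is new, unique, unknown or untested is made for them only; others in the source may bear on it.

Measured compounds:
Compound 1 `CCCCCCOc1ccc2c(Cl)ccnc2c1`: 2720 nM
Compound 2 `C=CCOc1ccc2c(NCCCN(C)C)ccnc2c1`: 3560 nM
Compound 3 `CC(C)COc1ccc2c(Cl)ccnc2c1`: 2680 nM

Three compounds have been run in a functional assay on RKO cells (Homo sapiens) for cytotoxicity, read by MTT assay, with a stated time of 48 h; a higher number here means a weaker inhibitor, a lower number a stronger inhibitor. Compound 1 `CCCCCCOc1ccc2c(Cl)ccnc2c1` gives 2720 nM. Compound 2 `C=CCOc1ccc2c(NCCCN(C)C)ccnc2c1` gives 3560 nM. Compound 3 `CC(C)COc1ccc2c(Cl)ccnc2c1` gives 2680 nM. The three numbers lie close together: compound 3 sits within the usual scatter of both compound 1 and compound 2, so no ordering among them can be drawn from these values.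

Compound 4 `CCOc1ccc2c(Cl)ccnc2c1` has not yet been measured. It differs from compound 3 in one place: methyl in place of isopropyl on a saturated chain carbon bound to an oxygen on an aromatic ring.

Going by the values given here, only one measured step bears on this change, and it acts at the same place on the same core: a 1.0-fold lower number from compound 1 to compound 3 (0.01 log units; within the scatter). Trimming the chain bound to that oxygen left the number where it was. Cutting the chain back further, from isopropyl to methyl at this carbon, is therefore expected to move the number little, with no step beyond the scatter in either direction; the expected step is a 1.0-fold higher number from compound 3 to compound 4 (0.02 log units; within the scatter). Compound 4 is thus estimated to give 2800 nM, within a range of 1500 nM to 5500 nM.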

Compound 4, half-maximal inhibitory concentration: 3870 nM
The estimate for compound 4 lay 1.4-fold (0.14 log units) below the measured number; the measured number falls inside the stated range.
By their numbers in this assay, from the lowest: compounds 3, 1, 2 and 4 (each within the scatter of the next).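

In this assay, going by these compounds alone, the cut from isopropyl to methyl on a saturated chain carbon bound to an oxygen on an aromatic ring gives a 1.4-fold higher number from compound 3 to compound 4 (0.16 log units; within the scatter) and this extends the flat picture at this position to a smaller group than the earlier compounds carried. Hydrogen in place of butyl on a saturated chain carbon, two bonds along the chain from that oxygen, gives a 1.4-fold higher number from compound 1 to compound 4 (0.15 log units; within the scatter) and so the ethoxy of compound 4 cannot be told apart from the longer chain of compound 1 or from the isobutoxy of compound 3. No measurement at hand offers an explanation for this flatness.

The compounds shown leave open whether a methoxy or a free hydroxyl on the shared core would stay within the scatter. They also leave open whether an amine or a carboxylic acid at the end of the chain would move the number beyond it.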